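From isopropyl ester to primary amide on the shared core

The compounds below may be only part of what the source reports. "The series", "measured", "known", "first", "only" and "open" are said of these compounds alone.

Three compounds sharing one core have been examined in a functional assay for inhibition of nuclear factor NF-kappa-B complex (Homo sapiens); on this read-out higher numbers stand for weaker inhibition and lower numbers for stronger inhibition. Compound 1 `COc1ccc2c(c1)OC(c1cc(OC)c(OC)c(OC)c1)C(CO)=C2` carries a hydroxymethyl group on a double-bonded ring carbon, and in this assay compound 1 reaches only a limit, > 50000 nM. Compound 2 `COc1ccc2c(c1)OC(c1cc(OC)c(OC)c(OC)c1)C(C(=O)OC(C)C)=C2` bears an isopropoxycarbonyl group in that place; in this assay compound 2 gives 11800 nM, the lowest of the two numbers available. Compound 3 `CCCCNC(=O)C1=Cc2ccc(OC)cc2OC1c1cc(OC)c(OC)c(OC)c1`, with a butylcarbamoyl group, gives in this assay 25500 nM. The steps of an at least 4.2-fold lower number from compound 1 to compound 2 (0.62 log units; beyond the scatter) and an at least 1.9-fold lower number from compound 1 to compound 3 (0.29 log units; that floor lies within the scatter) show both carbonyl derivatives coming in lower than the hydroxymethyl compound, while the step most comparable to the change now in question is a 2.2-fold higher number from compound 2 to compound 3 (0.33 log units; beyond the scatter).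

Compound 4 `COc1ccc2c(c1)OC(c1cc(OC)c(OC)c(OC)c1)C(C(N)=O)=C2` differs from compound 2 by amino in place of isopropoxy on a carbonyl carbon. Since exchanging isopropoxy for butylamino already moved the number upward by a 2.2-fold higher number from compound 2 to compound 3 (0.33 log units; beyond the scatter), removing the chain entirely to leave a bare amino group is expected to move it at least as far, with a real chance that only a limit is returned. Compound 4 is therefore estimated at 30000 nM, within 10000 nM to 90000 nM. This estimate corresponds to an expected step of a 2.5-fold higher number from compound 2 to compound 4 (0.41 log units; beyond the scatter).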

Compound 4, half-maximal inhibitory concentration: > 50000 nM
Compound 4: no number, only a limit; the forecaster's own chance of this, stated with the estimate: 30%; at least 1.6-fold (0.22 log units) between middle value and limit.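

Compound 4, with a bare amino group on the carbonyl carbon, returns only a limit in this assay, which shows that a carbonyl at this place does not by itself bring the lower numbers seen for compound 2 and compound 3. The step of an at least 4.2-fold higher number from compound 2 to compound 4 (0.62 log units; beyond the scatter) shows that the isopropoxy group cannot be exchanged for amino without a change beyond the scatter, whereas the step of an at least 1.9-fold higher number from compound 3 to compound 4 (0.29 log units; that floor lies within the scatter) has a floor within the scatter, so the effect of taking the butyl away from the amide-type nitrogen remains unresolved. The step from compound 1 to compound 4 cannot be read, and the two compounds share one limit: the limit of > 50000 nM in this assay, at which 2 of the 4 values shown sit.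

As far as these compounds go, it remains open whether numbers on this read-out follow the length of the chain on the carbonyl carbon, which a methylamino group, a hexylamino group or a methyl ester in the same place would help to settle. The compounds also leave open how a carboxylic acid on the double-bonded ring carbon would read in this assay.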